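A bromophenyl group replaces a chlorophenyl group

This account rests on a few compounds, and the source may have more. Where it says the series, first, only, none or still open, it means among the compounds named here.

Compound 1 `C=CCc1cc(O)c(O)c(CN2CCC(CCO)CC2)c1`: 54.4%
Compound 2 `C=CCc1ccc(OCc2cn(-c3ccccc3Cl)nn2)c(O)c1`: 46.6%
Compound 3 `C=CCc1cc(O)c(O)c(CN2CCC(Cc3ccccc3)CC2)c1`: 88.9%

All three compounds were tested in a functional assay on MIA PaCa-2 cells (Homo sapiens) for inhibition, read by MTT assay, with a stated time of 72 h, tested at 30 uM; on this read-out lower numbers stand for less inhibition of growth and higher numbers for more inhibition of growth at the one concentration tested. There, compound 2 gives 46.6%. That number lies within the usual scatter of compound 1 and well short of compound 3, so compound 2 sits in the lower part of this small set.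

Compound 4 `C=CCc1ccc(OCc2cn(-c3ccc(Br)cc3)nn2)c(O)c1` differs from compound 2 in one place: 4-bromophenyl in place of 2-chlorophenyl on an aromatic nitrogen. Here 4-bromophenyl takes the place of 2-chlorophenyl on an aromatic nitrogen of a five-membered aromatic ring with 3 nitrogen.

For the measured compounds named here, the only measured step is a number 34.5 percentage points higher from compound 1 to compound 3 (beyond the scatter). It is large, but it changes a different group on the core of compound 1, so it says little about this exchange. Going by the values given here, no measured step touches the group on that nitrogen, and the forecast therefore stays close to compound 2 with a wide margin. The expected result is a number 3.4 percentage points higher from compound 2 to compound 4 (within the scatter), which would not go beyond the scatter. Compound 4 is expected to give 50%, with an estimated range from 32% to 70%.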

Compound 4, percent growth inhibition at one concentration: 43.3%
Estimate against measurement, compound 4: 6.7 percentage points above; the range from low to high includes it.
By their numbers in this assay, from the lowest: compounds 4, 2 and 1 (each within the scatter of the next, the first and the last beyond it); then compound 3.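

In this assay, the exchange of 2-chlorophenyl for 4-bromophenyl on the aromatic nitrogen gives a number 3.3 percentage points lower from compound 2 to compound 4 (within the scatter), so this step does not separate the two groups. For the compounds shown here, it is also the first measured step at this position, which the earlier compounds could not provide. The two groups have the same count of heavy atoms but differ in both the halogen and where it sits, so this one step cannot show what either difference does alone, and nothing measured here gives a reason for the result.

As far as these compounds go, what stays open is whether a very different group on that nitrogen would move the number beyond the scatter. A phenyl group with no halogen, a benzyl group or a chain ending in an amine could each test this.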